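A few compounds are considered here, and "the series" means these few. Any claim that something is new, unique, unknown or untested is made for them only; others in the source may bear on it.

Values in a functional assay on FL5.12 cells (Mus musculus) for cytotoxicity, read by flow cytometry, with a stated time of 48 h; a lower number here means a stronger inhibitor, a higher number a weaker inhibitor:
- compound 1 `CCCCCCCCCCCC/C=C/c1ccc(CO[C@@H]2CN[C@@H](CO)C2)cc1`: 5100 nM
- compound 2 `CCCC/C=C/c1ccc(CO[C@H]2CN[C@H](CO)C2)cc1`: 5700 nM
- compound 3 `CCCCCCCCCC/C=C/c1ccc(CO[C@H]2CN[C@H](CO)C2)cc1`: 2400 nM

Compound 3 has the lowest of the three numbers, and compound 1 and compound 2 both lie above it beyond the scatter. Compound 4 `CCCCCCCCCCCC/C=C/c1ccc(CO[C@H]2CN[C@H](CO)C2)cc1` differs from compound 3 by one change: ethyl in place of hydrogen on a saturated chain carbon, ten or more bonds along the chain from a double-bonded chain carbon.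

Among the compounds with values here, one measured step bears on this change: a 2.4-fold lower number from compound 2 to compound 3 (0.38 log units; beyond the scatter). That step also lengthened the chain, but with hexyl, a larger addition than ethyl, and it was modest. A smaller step in the same direction is therefore expected in this assay, probably within the scatter. The estimated step is a 1.1-fold lower number from compound 3 to compound 4 (0.06 log units; within the scatter). Compound 4 is expected at 2100 nM, with an estimated range of 1100 nM to 4000 nM.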

Compound 4, half-maximal inhibitory concentration: 7300 nM
Beside the measured number, compound 4's estimate is 3.5-fold (0.54 log units) below it, and the stated range ends below it.
By their numbers in this assay, from the lowest: compound 3; then compounds 1, 2 and 4 (each within the scatter of the next).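

In this assay the ethyl addition runs against the earlier hexyl step: a 3.0-fold higher number from compound 3 to compound 4 (0.48 log units; beyond the scatter), where before a 2.4-fold lower number from compound 2 to compound 3 (0.38 log units; beyond the scatter). Lengthening therefore does not move the number in one direction, and with octyl in place of hydrogen the outcome is a 1.3-fold higher number from compound 2 to compound 4 (0.11 log units; within the scatter). At this chain length, changing configuration gives a 1.4-fold higher number from compound 1 to compound 4 (0.16 log units; within the scatter), a comparison of configuration alone: the fact that compounds 1 and 4 differ only in the configuration as drawn

Open, going by these compounds, is whether a chain ending in a carboxylic acid or an amine would follow the same course. Also open, on these data alone, is how the other configuration behaves with shorter chains.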